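Amino for methoxy on compound 2: expected inhibition of compound 3

The compounds below may be only part of what the source reports. "The series", "measured", "known", "first", "only" and "open" are said of these compounds alone.

In a functional assay on the whole organism for inhibition, with Rattus norvegicus as the target, at a dose of 0.3 mg/kg by the oral route (a higher number here means a stronger effect of the compound at the dose given, a lower number a weaker effect), compound 2 `COc1ccc(-c2cccc(C(=O)Nc3nn[nH]n3)n2)cc1` gives 4%. Compound 1 `CCCOc1cc(C(=O)Nc2nn[nH]n2)nc(-c2ccc(N)cc2)c1` gives 7% in this assay, which lies within the scatter of the value of compound 2, so the two cannot be told apart. Compound 3 `Nc1ccc(-c2cccc(C(=O)Nc3nn[nH]n3)n2)cc1` is not yet measured; it differs from compound 2 by amino in place of methoxy on an aromatic carbon. Among the measured compounds shown here, no step between measured compounds is known. Compound 1 also carries an amino and sits at 7% in this assay. The step from compound 2 to compound 3 is therefore expected to stay within the scatter a number 2 percentage points higher from compound 2 to compound 3 (within the scatter). Compound 3 is estimated at 6% in this assay, between -5% and 18%.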

Compound 3, a percentage reported as inhibition, in the whole organism at one dose (the size of the read-out at that dose, not a potency): 11%
Compound 3: middle estimate off by 5 percentage points, on the low side; the range from low to high includes it.
By their numbers in this assay, from the lowest: compounds 2, 1 and 3 (each within the scatter of the next).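

In this assay, amino in place of methoxy on an aromatic carbon, para to a large group, gives a number 7 percentage points higher from compound 2 to compound 3 (within the scatter), so this position takes either group without a readable change. With the amino held, hydrogen in place of propoxy gives a number 4 percentage points higher from compound 1 to compound 3 (within the scatter), so the propoxy also makes no readable difference. Nothing at hand explains either step.

On these data alone, whether a carboxylic acid or dimethylamino at the amino position, or a longer chain in place of propoxy, moves the inhibition beyond the scatter stays open.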